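Second nitrooxypropyl chain on the aromatic oxygen

A few compounds are considered here, and "the series" means these few. Any claim that something is new, unique, unknown or untested is made for them only; others in the source may bear on it.

The series shares the core seen in compound 1 `COc1cc(/C=C/C(=O)OCCCCCO[N+](=O)[O-])ccc1O`, which in a functional assay on NCI-H1792 cells (Homo sapiens) for cytotoxicity, read by resazurin assay, with a stated time of 72 h (a higher number here means a weaker inhibitor, a lower number a stronger inhibitor), gives 13000 nM. Compound 2 `COc1cc(/C=C/C(=O)OCCCO[N+](=O)[O-])ccc1O` gives 28500 nM in this assay, the highest of the two numbers; the step of a 2.2-fold higher number from compound 1 to compound 2 (0.34 log units; beyond the scatter) is modest but beyond the scatter. Compound 3 `COc1cc(/C=C/C(=O)OC(C)C)ccc1O` reaches only the limit > 50000 nM in this assay, in line with the limit of > 50000 nM in this assay, at which 1 of the 3 values shown sits. The step of an at least 1.7-fold higher number from compound 2 to compound 3 (0.24 log units; that floor lies within the scatter) therefore leaves the measured range.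

Compound 4 `COc1cc(/C=C/C(=O)OCCCO[N+](=O)[O-])ccc1OCCCO[N+](=O)[O-]` differs from compound 2 by 3-(nitrooxy)propyl in place of hydrogen on an oxygen on an aromatic ring. For the measured compounds named here, no measured step makes this change. The nearest are an at least 1.7-fold higher number from compound 2 to compound 3 (0.24 log units; that floor lies within the scatter), where isopropyl in place of 3-(nitrooxy)propyl on an oxygen next to a carbonyl group weakened inhibition, and a 2.2-fold higher number from compound 1 to compound 2 (0.34 log units; beyond the scatter), where nitrooxy in place of 2-(nitrooxy)ethyl weakened it modestly. Within these three compounds, more nitrooxyalkyl went with stronger inhibition. For compound 4 a modest lowering of the number in this assay is therefore expected, a 2.4-fold lower number from compound 2 to compound 4 (0.38 log units; beyond the scatter). The estimate for compound 4 is 12000 nM, with a range from 4000 nM to 35000 nM.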

Compound 4, half-maximal inhibitory concentration: > 50000 nM
Compound 4: no number, only a limit; the forecaster's own chance of this, stated with the estimate: 5%; middle value at least 4.1-fold (0.61 log units) away from the limit.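

In this assay compound 4 gives > 50000 nM, which is a limit of the assay and not a number. On the oxygen on the aromatic ring, 3-(nitrooxy)propyl in place of hydrogen gives an at least 1.7-fold higher number from compound 2 to compound 4 (0.24 log units; that floor lies within the scatter), so this change shows no lowering of the number, although the floor alone does not separate the two compounds. The link between more nitrooxyalkyl and stronger inhibition among compound 1, compound 2 and compound 3 does not extend to this position, compound 4 goes against it, and the series now sits at the limit more often: the limit of > 50000 nM in this assay, at which 2 of the 4 values shown sit.

From the compounds shown here alone, how far compound 4 lies past the limit stays open, as does any order between compound 3 and compound 4. Also open, going by these compounds, is whether a methyl group or a longer chain ending in an amine on this oxygen would give a number within the measured range.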